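Amide substituent and microsomal clearance in the chloro-benzoxazole series

The source may report more compounds than this note shows. Statements on the series, on what has been measured and on what is new or still open speak of the compounds shown alone.

Three compounds share the core of compound 1 `O=C(CCSc1nc2cc(Cl)ccc2o1)N1CCS(=O)(=O)C1` and differ at the amide end. In an ADME assay on microsomes from liver (Homo sapiens) for metabolic stability, read by LC-MS, using NADPH, with a stated time of 45 min, tested at 0.5 uM (a lower number here means slower removal, a higher number faster removal of the compound), compound 1 gives 1.7 mL/min/g, compound 2 `O=C(CCNc1nc2cc(Cl)ccc2o1)N1CCCC1` gives 2.3 mL/min/g, and compound 3 `O=C(CCSc1nc2cc(Cl)ccc2o1)NC1CCCC1` gives 11.3 mL/min/g. Compound 3 stands highest of the three: compound 2 lies nearest, compound 1 furthest. Going by the values given here, the one single-site step measured so far, a 6.6-fold higher number from compound 1 to compound 3 (0.82 log units; beyond the scatter), runs toward compound 3.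

Compound 4 `CC1CCCN1C(=O)CCSc1nc2cc(Cl)ccc2o1` is the next step: 2-methylpyrrolidin-1-yl in place of cyclopentylamino on a carbonyl carbon. This move carries the amide nitrogen back into a ring, as in compound 1 and compound 2, both of which sit well below compound 3 in this assay. The step of a 6.6-fold higher number from compound 1 to compound 3 (0.82 log units; beyond the scatter) is the measured change that bears most directly on it, since compound 4 partly reverses that swap. Among the compounds with values here, the values of compound 2 and compound 3 point the same way, although no step between them is computed here.

Within the data shown here, the expectation for compound 4 is therefore a lower number than compound 3 in this assay, a step of a 2.5-fold lower number from compound 3 to compound 4 (0.40 log units; beyond the scatter), somewhat smaller than the reverse of the measured step because a 6.6-fold higher number from compound 1 to compound 3 (0.82 log units; beyond the scatter) removed a ring that is not the one entering compound 4. Compound 4 is estimated at 4.5 mL/min/g, with a range of 2 mL/min/g to 10 mL/min/g.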

Compound 4, intrinsic clearance in a liver preparation (reported as CLH), per the amount of preparation that the assay uses: 8.5 mL/min/g
Estimate against measurement, compound 4: 1.9-fold (0.28 log units) below; measured number inside the range.
By their numbers in this assay, from the lowest: compounds 1 and 2 (each within the scatter of the next); then compounds 4 and 3 (each within the scatter of the next).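

Replacing cyclopentylamino with 2-methylpyrrolidin-1-yl takes away the amide hydrogen while keeping the count of heavy atoms, and in this assay this gives a 1.3-fold lower number from compound 3 to compound 4 (0.12 log units; within the scatter), so at this position on a carbonyl carbon the two groups cannot be told apart. Tying the amide nitrogen into a ring therefore does not by itself carry the number toward that of compound 1, as a 5.0-fold higher number from compound 1 to compound 4 (0.70 log units; beyond the scatter) stands beside a 6.6-fold higher number from compound 1 to compound 3 (0.82 log units; beyond the scatter), and among these three compounds it is 1,1-dioxo-1,3-thiazolidin-3-yl that separates from the two groups with a carbon-only substituent pattern. Nothing available gives a reason for this behaviour at the amide end.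

Still open, on these data alone, is what within 1,1-dioxo-1,3-thiazolidin-3-yl carries the separation, a question that the parent 1,3-thiazolidin-3-yl ring without its two oxygens or a morpholin-4-yl group on the core of compound 1 would address. Also open, as far as these compounds go, is what the methyl group contributes, since plain pyrrolidin-1-yl on that same core would be the direct partner of compound 4 in this assay.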